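A few compounds are considered here, and "the series" means these few. Any claim that something is new, unique, unknown or untested is made for them only; others in the source may bear on it.

Measured so far in a physicochemical assay for solubility, read by nephelometry, in phosphate buffer, measured as kinetic solubility, at pH 6.5; a higher number here means a more soluble compound, a lower number a less soluble compound:
- compound 1 `COc1ccc(-c2cc(-c3ccc(NS(C)(=O)=O)cc3)cnc2N)cn1`: 25 ug/mL
- compound 2 `COc1ccc(-c2cc(-c3ccc(S(C)(=O)=O)c(F)c3)cnc2N)cn1`: 6.3 ug/mL
- compound 3 `COc1ccc(-c2cc(-c3ccc4nccn4c3)cnc2N)cn1`: 12.5 ug/mL

Compound 1 sits at the top of the three numbers, but not clearly so: the value of compound 3 lies within the scatter of that of compound 1, so the two cannot be told apart on these data. Compound 2 is the one that separates, its number falling beyond the scatter below compound 1. All three share the same core; they differ only in the aryl group carried on it.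

Compound 4 `COc1ccc(-c2cc(-c3ccc(C(=O)O)cc3)cnc2N)cn1` has not yet been measured in this assay. Relative to compound 1 the change is carboxy in place of methanesulfonamido on an aromatic carbon. Within the data shown here, no pair of measured compounds traces this exact change, so there is no measured step to lean on, and the expectation rests on the structural change alone. The step from compound 1 to compound 4 is expected to be upward and beyond the scatter, at about a 2.8-fold higher number from compound 1 to compound 4 (0.45 log units; beyond the scatter). Compound 4 is therefore estimated at 70 ug/mL, with a plausible range from 25 ug/mL to 200 ug/mL, to be confirmed once the measurement is in hand.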

Compound 4, solubility: 6.3 ug/mL
For compound 4 the middle estimate is 11-fold (1.05 log units) above the measured one; the whole stated range lies above it.
By their numbers in this assay, from the lowest: compounds 2, 4, 3 and 1 (each within the scatter of the next, the first and the last beyond it).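

In this assay, among these compounds, carboxy in place of methanesulfonamido on an aromatic carbon, para to a large group, gives the first step that can be read at a single place: a 4.0-fold lower number from compound 1 to compound 4 (0.60 log units; beyond the scatter). Among the compounds shown here, it shows that the number responds to the group carried at this position, and that this exchange takes it down by more than the usual scatter, which compounds 1, 2 and 3 could not show, as they offer no pair differing in one place. For the compounds shown here, nothing measured so far bears on the reason for this step.

Still open, going by these compounds, is whether the step follows the carboxy group itself, or whether a methyl ester or a primary carboxamide at the same place would read like compound 4 or like compound 1, and where an amine or a longer chain there would fall. The exchange also rests on one pair on the shared core, so whether it runs the same way with a different group in place of the methoxy remains unsettled.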